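The compounds below may be only part of what the source reports. "The series", "measured", "known", "first", "only" and "open" are said of these compounds alone.

Measured so far:
- compound 1 `COc1cc(/C=C/C(=O)/C=C/c2cccc3ccccc23)ccc1OCc1cn(CCOc2cc(=O)oc3ccccc23)nn1` gives 85%
- compound 2 `COc1ccc(/C=C/C(=O)/C=C/c2ccc(OCc3cn(CCCCOc4cc(=O)oc5ccccc45)nn3)c(OC)c2)cc1OC` gives 53%
- compound 3 `COc1cc(/C=C/C(=O)/C=C/c2cccs2)ccc1OCc1cn(CCCCCOc2cc(=O)oc3ccccc23)nn1` gives 30%

In a functional assay on COLO 205 cells (Homo sapiens) for inhibition, read by sulforhodamine B assay, with a stated time of 48 h, tested at 50 uM (on this read-out lower numbers stand for less inhibition of growth and higher numbers for more inhibition of growth at the one concentration tested), compound 2 stands second highest of the three, with 53% as its value. Compound 3 lies lower and compound 1 higher, both beyond the usual scatter.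

The next compound to read is compound 4 `COc1ccccc1/C=C/C(=O)/C=C/c1ccc(OCc2cn(CCCCOc3cc(=O)oc4ccccc34)nn2)c(OC)c1`, not yet measured. Its change from compound 2 is 2-methoxyphenyl in place of 3,4-dimethoxyphenyl on a double-bonded chain carbon bound to a double-bonded chain carbon, with 2-methoxyphenyl in place of 3,4-dimethoxyphenyl on a double-bonded chain carbon bound to a double-bonded chain carbon. The rest of the structure stays the same.

Among the measured compounds shown here, no two measured compounds differ in one place only, so the series offers no direct measure of this step. In this assay only a small upward step, not beyond the scatter, is expected, and the uncertainty is wide. The expected step is a number 4 percentage points higher from compound 2 to compound 4 (within the scatter), a rough estimate.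

For compound 4 the estimated value is 57%, expected to fall between 35% and 80%.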

Compound 4, percent growth inhibition at one concentration: 47%
The estimate for compound 4 lay 10 percentage points above the measured number; the range from low to high includes it.
By their numbers in this assay, from the lowest: compound 3; then compounds 4 and 2 (each within the scatter of the next); then compound 1.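

In this assay, among the compounds shown here, the replacement of 3,4-dimethoxyphenyl by 2-methoxyphenyl on a double-bonded chain carbon bound to a double-bonded chain carbon gives the first one-place comparison: a number 6 percentage points lower from compound 2 to compound 4 (within the scatter). At this position, the two aryl groups cannot be told apart at the one concentration tested, so this change gives no clear separation between compound 2 and compound 4. Nothing at hand explains this result.

Steps from compound 1 or compound 3 to the other compounds cannot be read, as each differs from them in more than one place. As far as these compounds go, whether a phenyl group carrying an amine or a carboxylic acid at this same place would separate from compound 2 beyond the scatter remains open.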